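Piperidine in Place of Piperazine: Expected Gain in Stability

This account rests on a few compounds, and the source may have more. Where it says the series, first, only, none or still open, it means among the compounds named here.

Measured compounds in an ADME assay on microsomes from liver (Mus musculus) for metabolic stability, read by LC-MS, using NADPH, with stated times of 15 min and 60 min, tested at 4.6 uM; on this read-out lower numbers stand for a shorter-lived compound and higher numbers for a longer-lived compound:
- compound 1, `CN1CCN(c2ccc3c(c2)oc(=O)n3C(=O)NCCCCc2ccccc2)CC1=O`: 0.5 h
- compound 2, `CCN1CCC(c2ccc3c(c2)oc(=O)n3C(=O)NCCCCc2ccccc2)CC1`: 1 h
- compound 3, `CCN1CCN(c2ccc3c(c2)oc(=O)n3C(=O)NCCCCc2ccccc2)CC1`: < 0.0834 h

Compound 3 stands at the bottom of the three: its result in this assay is a limit of the measurement and not a number, namely (the limit of < 0.0834 h in this assay, at which 1 of the 3 values shown sits). The step of an at least 5.9-fold lower number from compound 1 to compound 3 (0.77 log units; beyond the scatter) and the step of an at least 11-fold lower number from compound 2 to compound 3 (1.07 log units; beyond the scatter) both lead down to that limit, the second of them large, while a 2.0-fold higher number from compound 1 to compound 2 (0.30 log units; within the scatter) stays within the scatter.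

Compound 4, `CC(C)N1CCC(c2ccc3c(c2)oc(=O)n3C(=O)NCCCCc2ccccc2)CC1`, is not yet measured. It differs from compound 3 by 1-isopropylpiperidin-4-yl in place of 4-ethylpiperazin-1-yl on an aromatic carbon. The step of an at least 11-fold lower number from compound 2 to compound 3 (1.07 log units; beyond the scatter) bears most directly on this change, since compound 4 carries a piperidine of the same kind as compound 2, differing from it only by the isopropyl in place of the ethyl on the ring nitrogen; that step is expected to be reversed. Compound 4 is therefore expected to give 0.9 h in this assay, with a range from 0.3 h to 2.5 h, a step of an at least 10-fold higher number from compound 3 to compound 4 (1.03 log units; beyond the scatter) upward from compound 3, with its scale anchored by compound 2 at 1 h.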

Compound 4, half-life: 1 h
Compound 4: middle estimate off by 1.1-fold (0.05 log units), on the low side; the measured number falls inside the stated range.
By their numbers in this assay, from the lowest: compounds 1, 2 and 4 (each within the scatter of the next). At a limit, below all of these: compound 3.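

Compound 4 shows that the piperidine result in this assay does not rest on the ethyl group alone: with isopropyl in place of ethyl on the ring nitrogen, the step is no change at the digits printed from compound 2 to compound 4 (within the scatter). Replacing 4-ethylpiperazin-1-yl with 1-isopropylpiperidin-4-yl gives an at least 11-fold higher number from compound 3 to compound 4 (1.07 log units; beyond the scatter), while replacing the 4-methyl-3-oxopiperazin-1-yl group with it gives a 2.0-fold higher number from compound 1 to compound 4 (0.30 log units; within the scatter). Compound 3 remains a limit of the measurement and not a number: the limit of < 0.0834 h in this assay, at which 1 of the 4 values shown sits.

From the compounds shown here alone, it remains open whether a hydrogen, a cyclopropyl group or a 2-hydroxyethyl group on the piperidine nitrogen would give a half-life in the same range. Also open, going by these compounds, is whether isopropyl in place of ethyl on the piperazine nitrogen of compound 3 would change its result.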